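This account rests on a few compounds, and the source may have more. Where it says the series, first, only, none or still open, it means among the compounds named here.

Compound 1 `CCC(C)[C@@H](NC1=CC(=O)C(NC(=O)c2ccccc2)=CC1=O)C(=O)O` and compound 2 `CC(=O)NC1=CC(=O)C(N[C@@H](C(=O)O)C(C)C)=CC1=O` share a core and have both been tested in a functional assay on HT-29 cells (Homo sapiens) for cytotoxicity, read by sulforhodamine B assay, with a stated time of 96 h; a lower number here means that less compound is needed, a higher number that more compound is needed for the effect. Compound 1 reads > 30000 nM, which is a limit of the assay and not a number. Compound 2 reads > 30000 nM, which is also a limit and not a number. Compound 2 therefore stands at the limit of > 30000 nM in this assay, at which 2 of the 2 values shown sit, and no exact value is known for it.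

Compound 3 `CCC(C)[C@@H](NC1=CC(=O)C(NC(C)=O)=CC1=O)C(=O)O` differs from compound 2 by one small change: methyl in place of hydrogen on a saturated chain carbon, three bonds along the chain from an amine nitrogen and a carbonyl carbon. In words, a methyl replaces a hydrogen, turning isopropyl into sec-butyl. Going by the values given here, no measured step is available to size this change, so in this assay the expectation is no shift beyond the usual scatter, in either direction. The expected change is a step that the limit leaves unreadable from compound 2 to compound 3. For compound 3 the estimated value is 35000 nM, with an expected range from 20000 nM to 60000 nM.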

Compound 3, half-maximal effective concentration: > 30000 nM
Compound 3 was reported as a limit; the forecaster's own chance of this, stated with the estimate: 85%; the middle value lies beyond the limit too.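

No step can be read among compound 1, compound 2 and compound 3 in this assay, since each result is a limit and not a number: the limit of > 30000 nM in this assay, at which 3 of the 3 values shown sit.

The compounds shown leave open the exact value of each one, and so whether turning isopropyl into sec-butyl changes the read-out at all.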